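Oxolane Amide in Place of Benzyl Amide

The source may hold more compounds than are shown below. What is called first, only, known or untested is meant among the compounds shown, and "the series" means these compounds.

Compound 1 `Cc1cc(C(=O)Nc2ccc(F)cc2)nn1Cc1cc(Cl)ccc1OCc1ccccc1` carries a 4-fluorophenyl group on the amide-type nitrogen, and in a physicochemical assay for lipophilicity, at pH 7.4 (on this read-out lower numbers stand for lower lipophilicity and higher numbers for higher lipophilicity), compound 1 gives 3. Compound 2 `Cc1cc(C(=O)NCc2ccccc2)nn1Cc1cc(Cl)ccc1OCc1ccccc1` bears benzyl in that place. In this assay compound 2 gives > 3.7, which is a limit of the assay and not a number. Among the compounds with values here, the single measured step, a number at least 0.70 log units higher from compound 1 to compound 2 (beyond the scatter), is accordingly only a lower bound, since it rests on (the limit of > 3.7 in this assay, at which 1 of the 2 values shown sits); where compound 2 truly stands above that limit is not known.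

Compound 3 `Cc1cc(NC(=O)C2CCOC2)nn1Cc1cc(Cl)ccc1OCc1ccccc1` differs from compound 2 in one place: ((oxolan-3-yl)carbonyl)amino in place of benzylcarbamoyl on an aromatic carbon. Within the data shown here, no measured step mirrors this exchange. Among the measured compounds shown here, the only step in hand concerns a swap of one group on the amide-type nitrogen for another, whereas here the whole benzylcarbamoyl group leaves and a group with a five-membered non-aromatic ring with one hetero atom and two hydrogen-bond acceptors enters. A downward step in this assay beyond the scatter is therefore expected, estimated as a number at least 1.40 log units lower from compound 2 to compound 3 (beyond the scatter). Compound 3 is expected to give 2.3, with a likely range from 1.6 to 3.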

Compound 3, distribution coefficient: > 3.7
Compound 3: only a limit was reported (the forecaster's own chance of this, stated with the estimate: 5%); middle value at least 1.40 log units away from the limit.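

In this assay compound 3 gives > 3.7 as a limit of the assay and not a number. Placing ((oxolan-3-yl)carbonyl)amino in place of (4-fluorophenyl)carbamoyl on this aromatic carbon gives a number at least 0.70 log units higher from compound 1 to compound 3 (beyond the scatter) and this is only a lower bound, so a group with a five-membered non-aromatic ring and no aromatic ring at this position also reaches the limit of the read-out, as benzylcarbamoyl did in compound 2. The step from compound 2 to compound 3 cannot be read, because both compounds sit at the same limit: (the limit of > 3.7 in this assay, at which 2 of the 3 values shown sit).

As far as these compounds go, how far compound 2 and compound 3 truly stand beyond that limit, and which of the two has the higher true value, remains open. From the compounds shown here alone, it is also open whether a carboxylic acid or a primary amine on this aromatic carbon, in place of the ((oxolan-3-yl)carbonyl)amino group, would bring the read-out back to a number that can be compared with the value of compound 1.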